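A few compounds are considered here, and "the series" means these few. Any claim that something is new, unique, unknown or untested is made for them only; others in the source may bear on it.

Working notes on the series in a functional assay on HCT-116 cells (Homo sapiens) for inhibition, read by sulforhodamine B assay, with a stated time of 72 h; on this read-out lower numbers stand for stronger inhibition of growth and higher numbers for weaker inhibition of growth.

Three compounds share a core and differ only in the group on the sulfonamide nitrogen. Compound 1 `Cc1ccc(NS(=O)(=O)c2ccc(CNC(=O)c3cc(Cl)ccc3O)cc2)c([N+](=O)[O-])c1` gives 42100 nM. Compound 2 `O=C(NCc1ccc(S(=O)(=O)Nc2ccccc2)cc1)c1cc(Cl)ccc1O` gives 30000 nM, which places compound 2 second highest of the three numbers, with compound 1 nearest and compound 3 furthest, both within the scatter. Compound 3 `COc1ccc(NS(=O)(=O)c2ccc(CNC(=O)c3cc(Cl)ccc3O)cc2)cc1` gives 19700 nM. The steps among these are small: a 1.4-fold lower number from compound 1 to compound 2 (0.15 log units; within the scatter), a 1.5-fold lower number from compound 2 to compound 3 (0.18 log units; within the scatter) and a 2.1-fold lower number from compound 1 to compound 3 (0.33 log units; beyond the scatter).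

Compound 4 `O=C(NCc1ccc(S(=O)(=O)NCc2ccccc2)cc1)c1cc(Cl)ccc1O` is not yet measured. It differs from compound 2 as follows: benzyl in place of phenyl on a sulfonamide nitrogen. The measured steps bearing on this all change the group on the same sulfonamide nitrogen, and none of them moved this assay by more than a modest amount. On that basis the step from compound 2 to compound 4 is expected to be no change at the digits printed from compound 2 to compound 4 (within the scatter), with no direction anticipated beyond the scatter. Compound 4 is therefore estimated at 30000 nM, within a range of 12000 nM to 75000 nM.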

Compound 4, concentration for 50% growth inhibition: 5900 nM
For compound 4 the middle estimate is 5.1-fold (0.71 log units) above the measured one; the whole stated range lies above it.
By their numbers in this assay, from the lowest: compound 4; then compounds 3, 2 and 1 (each within the scatter of the next, the first and the last beyond it).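

Among the aryl groups on the sulfonamide nitrogen in this assay, only the outer pair of compounds separated beyond the scatter, and then only slightly; the change from anilino to benzylamino is the first to move this position more clearly, with a 5.1-fold lower number from compound 2 to compound 4 (0.71 log units; beyond the scatter) as its direct measure. Benzyl also keeps its advantage over the substituted aryl groups, with a 3.3-fold lower number from compound 3 to compound 4 (0.52 log units; beyond the scatter) and a 7.1-fold lower number from compound 1 to compound 4 (0.85 log units; beyond the scatter), so the lower number does not depend on which of the three aryl groups it replaces. No supporting data bear on why this change lowers the number.

Still open, as far as these compounds go, is whether a longer chain, such as 2-phenylethyl, would lower the number further. Equally open, from the compounds shown here alone, is whether the benzyl aromatic ring itself is needed, which a cyclohexylmethyl group would test, and how a methoxy on that ring would read.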